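The compounds below may be only part of what the source reports. "The series", "measured", "known", "first", "only" and "open" are said of these compounds alone.

Values so far in an ADME assay on Vero cells (Chlorocebus sabaeus) for cytotoxicity, read by MTT assay, with a stated time of 72 h; a higher number here means that more compound is tolerated, a lower number that less compound is tolerated
- Compound 1 `COc1c(N2C[C@H]3CCCN(C(=O)Cn4cc(CN5C(=O)C(=O)c6ccccc65)nn4)[C@H]3C2)c(F)cc2c(=O)c(C(=O)O)cn(C3CC3)c12` gives 32 ug/mL
- Compound 2 `COc1c(N2C[C@H]3CCCN(C(=O)Cn4cc(CN5C(=O)C(=O)c6cc(F)ccc65)nn4)[C@H]3C2)c(F)cc2c(=O)c(C(=O)O)cn(C3CC3)c12` gives 16 ug/mL
- Compound 3 `COc1c(N2C[C@H]3CCCN(C(=O)Cn4cc(CN5C(=O)/C(=N/O)c6ccccc65)nn4)[C@H]3C2)c(F)cc2c(=O)c(C(=O)O)cn(C3CC3)c12` gives 32 ug/mL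

Compound 3 stands level with compound 1 at the digits shown, and all three values lie within the scatter of one another. The change from compound 3 to compound 4 `COc1c(N2C[C@H]3CCCN(C(=O)Cn4cc(CN5C(=O)/C(=N/O)c6cccc(F)c65)nn4)[C@H]3C2)c(F)cc2c(=O)c(C(=O)O)cn(C3CC3)c12` is fluoro in place of hydrogen on an aromatic carbon, in a six-membered aromatic ring of carbon only, ortho to a fused ring and meta to a fused ring.

Going by the values given here, two measured steps bear on this. The same exchange of hydrogen for fluoro appears in a 2.0-fold lower number from compound 1 to compound 2 (0.30 log units; within the scatter), a step within the scatter, although the fluoro there stands on a different aromatic carbon and the parent is compound 1 rather than compound 3. The group exchange that separates the parents gives no change at the digits printed from compound 1 to compound 3 (within the scatter), also within the scatter. Among the compounds with values here, no measured pair shows fluoro added to compound 3 itself.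

On that basis only a small drift towards a lower number is expected, nothing beyond the scatter. The expected outcome is a 1.3-fold lower number from compound 3 to compound 4 (0.12 log units; within the scatter), with the direction uncertain. In this assay compound 4 is estimated at 24 ug/mL, with an expected range from 12 ug/mL to 48 ug/mL.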

Compound 4, half-maximal cytotoxic concentration: 16 ug/mL
The estimate for compound 4 lay 1.5-fold (0.18 log units) above the measured number; the range from low to high includes it.
By their numbers in this assay, from the lowest: compounds 2, 4, 1 and 3 (each within the scatter of the next).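

In this assay, fluoro in place of hydrogen on this aromatic carbon, ortho to a fused ring and meta to a fused ring, gives a 2.0-fold lower number from compound 3 to compound 4 (0.30 log units; within the scatter). Going by these compounds alone, the only earlier reading of this exchange stood on a different aromatic carbon and on a different parent, and the two readings now agree: the same change on two cores in this assay, a 2.0-fold lower number (0.30 log units; within the scatter) from compound 1 to compound 2 and a 2.0-fold lower number (0.30 log units; within the scatter) from compound 3 to compound 4, 1.0-fold (0.00 log units) apart, within the scatter of two such steps Each step on its own stays within the scatter, however, so the match is a consistent observation across two cores and does not establish a real effect of fluoro on the number in this assay.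

The compounds shown do not separate the place of the fluoro from the parent that carries it, since each parent has fluoro on only one carbon, and a version of compound 3 with fluoro on the carbon used in compound 2 would be needed to do so. They also leave open whether a larger group on this same carbon, such as chloro, methoxy or an amine, would give a step beyond the scatter.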